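This account rests on a few compounds, and the source may have more. Where it says the series, first, only, none or still open, it means among the compounds named here.

Measured so far:
compound 1 `Fc1ccc(Cn2cc(CSC(=S)N3CCNCC3)nn2)cc1`. In a functional assay on ECa-109 cells (Homo sapiens) for inhibition, read by MTT assay, with a stated time of 72 h (a lower number here means a stronger inhibitor, a higher number a weaker inhibitor), compound 1 gives > 128000 nM, which is a limit of the assay rather than a number.
compound 2 `O=C(OCc1ccccc1)N1CCN(C(=S)SCc2cn(Cc3ccc(Cl)cc3)nn2)CC1`. In this assay compound 2 gives > 128000 nM, again a limit.
compound 3 `S=C(SCc1cn(Cc2ccc(Cl)c(Cl)c2)nn1)N1CCNCC1`. In this assay compound 3 gives > 128000 nM, also a limit.

Compound 3 therefore stands nowhere on a readable scale: its value is a limit, and the two other values shown are limits as well, so that all three values sit at one point (the limit of > 128000 nM in this assay, at which 3 of the 3 values shown sit). For the measured compounds named here, the only single-place step among the measured compounds, a step that the two limits leave unreadable from compound 1 to compound 3, is left unreadable by the two limits at its ends, and nothing can be said about its size or direction.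

Compound 4 `S=C(SCc1cn(Cc2ccc(Cl)cc2)nn1)N1CCNCC1` differs from compound 3 by hydrogen in place of chloro on an aromatic carbon. Compound 2 carries the same 4-chlorophenyl group as compound 4 with a further group on the core, and compound 2 sits at the limit. Going by the values given here, no measured step has yet produced a number, so no size of step can be derived for the removal of the chloro group.

Compound 4 is expected to remain at the limit in this assay, the estimated step that the limit leaves unreadable from compound 3 to compound 4 being unreadable. The estimate for compound 4 is 200000 nM, with a range from 100000 nM to 600000 nM, most likely reported as a limit.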

Compound 4, half-maximal inhibitory concentration: > 128000 nM
Compound 4: a limit, no number; the forecaster's own chance of this, stated with the estimate: 85%; the middle value does not contradict the limit.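

In this assay compound 4 gives > 128000 nM, a limit and not a number. No step from compound 1, compound 2 or compound 3 to compound 4 can be read, and all four compounds sit together: the limit of > 128000 nM in this assay, at which 4 of the 4 values shown sit.

The compounds shown leave open the size and direction of each of these changes in inhibition.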